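The source may report more compounds than this note shows. Statements on the series, on what has been measured and on what is new or still open speak of the compounds shown alone.

Values in a functional assay on HL-60 cells (Homo sapiens) for antiproliferative activity, read by XTT assay, with a stated time of 72 h; on this read-out higher numbers stand for weaker inhibition and lower numbers for stronger inhibition:

- compound 1 `CSc1ncnc2c1c(-c1ccoc1)cn2[C@@H]1O[C@H](CO)[C@@H](O)[C@H]1O`: 360 nM
- compound 2 `C#Cc1cn([C@@H]2O[C@H](CO)[C@@H](O)[C@H]2O)c2ncnc(SC)c12`: 50 nM
- compound 3 `CNc1ncnc2c1c(-c1ccco1)cn2[C@@H]1O[C@H](CO)[C@@H](O)[C@H]1O`: 620 nM

Compound 3 and compound 1 lie within the usual scatter of each other, so these data cannot separate them. Compound 2 has the clearly lower number of the three, and lower here means stronger inhibition.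

The next compound, compound 4 `CNc1ncnc2c1c(-c1ccccc1)cn2[C@@H]1O[C@H](CO)[C@@H](O)[C@H]1O`, differs from compound 3 in one place, with phenyl in place of furan-2-yl on an aromatic carbon.

Within the data shown here, only one measured step involves a change at this carbon: a 7.2-fold lower number from compound 1 to compound 2 (0.86 log units; beyond the scatter), where ethynyl replaces furan-3-yl. It shows that the read-out can respond to a change there. Among the measured compounds shown here, it is a weak guide, however, since that pair carries a different group elsewhere on the core and no measured step swaps one ring for another. In that step the number fell when the ring left, so a larger ring entering gives a faint hint the other way.

A modest move towards weaker inhibition in this assay is therefore expected, an estimated 2.3-fold higher number from compound 3 to compound 4 (0.35 log units; beyond the scatter). For compound 4 the estimate is 1400 nM, with an expected range of 350 nM to 6000 nM.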

Compound 4, half-maximal inhibitory concentration: > 20000 nM
Compound 4 was reported as a limit (the forecaster's own chance of this, stated with the estimate: 12%); at least 14-fold (1.15 log units) between middle value and limit.
By their numbers in this assay, from the lowest: compound 2; then compounds 1 and 3 (each within the scatter of the next). At a limit, above all of these: compound 4.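

In this assay, replacing furan-2-yl with phenyl on this aromatic carbon gives an at least 32-fold higher number from compound 3 to compound 4 (1.50 log units; beyond the scatter), which shows that one aromatic ring cannot be exchanged freely for another here. Among these compounds, the only earlier step at this carbon, a 7.2-fold lower number from compound 1 to compound 2 (0.86 log units; beyond the scatter), replaced a ring with ethynyl, and it said nothing about a swap of one ring for another. Compound 4 is reported as a limit and not as a number: the limit of > 20000 nM in this assay, at which 1 of the 4 values shown sits.

This single change alters two things at once, since a five-membered ring with an oxygen leaves and a six-membered ring of carbon only enters, and the compounds shown do not separate these two differences. Open questions are how thiophen-2-yl, a five-membered ring with sulfur in place of the oxygen, and pyridin-3-yl, a six-membered ring with one nitrogen, would compare with furan-2-yl and phenyl on the core shared by compound 3 and compound 4.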